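The source may report more compounds than this note shows. Statements on the series, on what has been measured and on what is new or still open speak of the compounds shown alone.

In an in vivo functional assay on the whole organism for inhibition of 3-hydroxy-3-methylglutaryl-coenzyme A reductase (Rattus norvegicus), at a dose of 0.2 mg/kg by the oral route (on this read-out higher numbers stand for a stronger effect at the one dose given and lower numbers for a weaker effect), three compounds have been measured. Compound 1, `Cc1nn(C(C)(C)C)c2nc(C3CC3)c(/C=C/[C@@H](O)C[C@@H](O)CC(=O)O)c(-c3ccc(F)cc3)c12`, gives 4.5%. Compound 2, `Cc1nn(C)c2nc(C3CC3)c(/C=C/[C@@H](O)C[C@@H](O)CC(=O)O)c(-c3ccc(F)cc3)c12`, gives 35.5%. Compound 3, `CC(C)c1nc2cc(-c3ccccc3)nn2c(-c2ccc(F)cc2)c1/C=C/[C@@H](O)C[C@@H](O)CC(=O)O`, gives -1.4%. Compound 2 stands highest of the three numbers: the step of a number 31 percentage points higher from compound 1 to compound 2 (beyond the scatter) is large and beyond the scatter, and the gap between compound 2 and compound 3 is also beyond the scatter, so compound 2 is the most active of the three in this assay.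

Compound 4, `Cc1nn(C)c2nc(C(C)C)c(/C=C/[C@@H](O)C[C@@H](O)CC(=O)O)c(-c3ccc(F)cc3)c12`, differs from compound 2 in one place: isopropyl in place of cyclopropyl on an aromatic carbon. Within the data shown here, the only measured step, from compound 1 to compound 2, concerns a group on an aromatic nitrogen, not the aromatic carbon changed here, so no measured step speaks directly to this change. With nothing to point either way, a step within the scatter is expected, a number 5.5 percentage points lower from compound 2 to compound 4 (within the scatter), if anything slightly downward. For compound 4 the expected result in this assay is 30%, with a likely range from 10% to 50%.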

Compound 4, a percentage reported as inhibition, in the whole organism at one dose (the size of the read-out at that dose, not a potency): 41.1%
For compound 4 the middle estimate is 11.1 percentage points below the measured one, and the stated range covers the measured number.
By their numbers in this assay, from the lowest: compounds 3 and 1 (each within the scatter of the next); then compounds 2 and 4 (each within the scatter of the next).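

Putting isopropyl in place of cyclopropyl on the aromatic carbon next to the ring nitrogen gives a number 5.6 percentage points higher from compound 2 to compound 4 (within the scatter) in this assay. The earlier step changed only the group on an aromatic nitrogen, whereas this one shows that at this carbon the three-membered ring can be opened without a change that stands out from the scatter. At this single dose, therefore, the ring itself is not needed for the effect, and the two groups cannot be told apart. Nothing available explains why they read alike.

From the compounds shown here alone, both groups hold carbon only, so it stays open whether an amine, a methoxy group or a longer chain on this carbon would keep the effect. A single dose also leaves open whether compound 2 and compound 4 differ in potency.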